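The source may hold more compounds than are shown below. What is called first, only, known or untested is meant among the compounds shown, and "the series" means these compounds.

Compound 1 `COc1ccc(C2=NN(c3nc(-c4ccc(OC)cc4)cs3)C(c3cccs3)C2)cc1` gives 16200 nM in a functional assay on MCF7 cells (Homo sapiens) for antiproliferative activity, read by MTT assay, with a stated time of 48 h; on this read-out higher numbers stand for weaker inhibition and lower numbers for stronger inhibition.
Compound 2 `Brc1ccc(C2=NN(c3nc(-c4ccc(Br)cc4)cs3)C(c3cccs3)C2)cc1` gives 28300 nM in this assay.
Compound 3 `Clc1ccc(C2=NN(c3nc(-c4ccc(Br)cc4)cs3)C(c3cccs3)C2)cc1` gives 14700 nM in this assay.

All three compounds share one core and differ only in the groups on their two phenyl rings. Among the compounds with values here, the step of a 1.9-fold lower number from compound 2 to compound 3 (0.28 log units; within the scatter) is the only single change among the measured pair, and it stays within the scatter. Compound 3 sits within the scatter of compound 1 and of compound 2 alike, so none of the three separates from the others on the numbers shown.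

Compound 4 `COc1ccc(-c2csc(N3N=C(c4ccc(Cl)cc4)CC3c3cccs3)n2)cc1` is reached from compound 3 by methoxy in place of bromo on an aromatic carbon. Within the data shown here, no measured pair isolates this exact change. Compound 1 carries methoxy on both phenyl rings and compound 2 carries bromo on both, and their values fall within the scatter of each other, which gives no sign that exchanging bromo for methoxy moves the read-out. Compound 3 is therefore expected to pass to compound 4 with a step of a 1.1-fold lower number from compound 3 to compound 4 (0.02 log units; within the scatter) that stays inside the scatter. Compound 4 is expected to give 14000 nM in this assay, with a range from 6000 nM to 35000 nM.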

Compound 4, half-maximal inhibitory concentration: 2480 nM
Estimate against measurement, compound 4: 5.6-fold (0.75 log units) above; the measured number lies below the stated range.
By their numbers in this assay, from the lowest: compound 4; then compounds 3, 1 and 2 (each within the scatter of the next).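

In this assay, the methoxy at this place, on an aromatic carbon para to a large group, gives a clear change only when the other phenyl ring carries chloro: the exchange of the 4-bromophenyl for the 4-methoxyphenyl yields a 5.9-fold lower number from compound 3 to compound 4 (0.77 log units; beyond the scatter), and with the 4-methoxyphenyl kept, chloro in place of methoxy on the other ring yields a 6.5-fold lower number from compound 1 to compound 4 (0.82 log units; beyond the scatter), both beyond the scatter. Neither group does this alone, since compound 1 carries the same methoxy and compound 3 the same chloro, yet those two stay within the scatter of each other, so among these compounds the lower number goes with the pairing of methoxy and chloro, which the earlier compounds, with their near-equal values, gave no sign of. Nothing in the data on hand explains why this pairing reads differently from the others.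

Going by these compounds, whether the same two groups, exchanged between the two phenyl rings, would read the same remains open. So does whether the effect of the chloro on the other ring would hold with an amine, a hydroxyl or a longer ether chain at this position in place of the methoxy.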